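The source may report more compounds than this note shows. Statements on the series, on what has been measured and on what is new or still open speak of the compounds shown alone.

Measured so far:
compound 1 `CC(C)(C)c1cc(NC(=O)Nc2ccc(Cl)cc2)n(-c2ccc(C(F)(F)F)cc2)n1`: 0.6 degrees C
compound 2 `CC(C)(C)c1cc(NC(=O)Nc2ccc(Cl)cc2)n(-c2ccc(OC(F)(F)F)cc2)n1`: 0.9 degrees C

Among the measured compounds shown here, compound 2 holds the higher of the two numbers in an assay on isolated protein for inhibition of Ephrin type-A receptor 2 (Homo sapiens), read by thermal shift assay, tested at 10 uM (a lower number here means that the compound stabilises the target less, a higher number that the compound stabilises the target more against heat), though its only neighbour, compound 1, sits a number 0.30 degrees C higher from compound 1 to compound 2 (within the scatter) and so within the scatter of it. Compound 3 `CC(C)(C)c1cc(NC(=O)Nc2ccc(Cl)cc2)n(-c2ccc(C#N)cc2)n1` differs from compound 2 by cyano in place of trifluoromethoxy on an aromatic carbon. For the measured compounds named here, the one step measured is the only one that bears on this change, since it also swaps the group on the same aromatic carbon, and it gave a number 0.30 degrees C higher from compound 1 to compound 2 (within the scatter), a shift inside the scatter. On that basis no step beyond the scatter is expected from compound 2 to compound 3, and the direction cannot be read from the data. Compound 3 is therefore estimated at 0.7 degrees C, within a range of -0.5 degrees C to 1.9 degrees C, an expected step of a number 0.20 degrees C lower from compound 2 to compound 3 (within the scatter).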

Compound 3, shift of the target's melting temperature: 0.8 degrees C
Beside the measured number, compound 3's estimate is 0.10 degrees C below it; low and high end bracket the measured number.
By their numbers in this assay, from the lowest: compounds 1, 3 and 2 (each within the scatter of the next).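

In this assay the swap to cyano, with 2 heavy atoms against the 5 of trifluoromethoxy, gives a step of a number 0.10 degrees C lower from compound 2 to compound 3 (within the scatter) and, against trifluoromethyl, a step of a number 0.20 degrees C higher from compound 1 to compound 3 (within the scatter). Among the compounds shown here, three different groups on this aromatic carbon, para to a large group, now stand within the scatter of one another, where the earlier pair could show this for only two groups, and the smaller cyano fits in that same narrow band. Nothing available here bears on why these groups read alike. The compounds shown leave open whether an amine or a carboxylic acid at this place would give a step beyond the scatter. They also leave open whether a change elsewhere on the shared core would do so.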